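The compounds below may be only part of what the source reports. "The series", "measured", "known", "first", "only" and "open" are said of these compounds alone.

In a functional assay on A549 cells (Homo sapiens) for antiproliferative activity, read by MTT assay, with a stated time of 48 h (on this read-out higher numbers stand for weaker inhibition and lower numbers for stronger inhibition), compound 1 `COc1ccc2[nH]c(-c3cn(-c4ccccc4)nc3-c3ccc(F)cc3)nc2c1` gives 1960 nM and compound 2 `Fc1ccc(-c2nn(-c3ccccc3)cc2-c2nc3cc(C(F)(F)F)ccc3[nH]2)cc1` gives 2340 nM, so compound 2 stands within the scatter of compound 1. Compound 3 `COc1ccc(-c2nn(-c3ccccc3)cc2-c2nc3cc(C(F)(F)F)ccc3[nH]2)cc1` differs from compound 2 in one place, with methoxy in place of fluoro on an aromatic carbon, para to a large group: methoxy in place of fluoro on an aromatic carbon. For the measured compounds named here, no measured step covers this 4-fluorophenyl to 4-methoxyphenyl change. Going by the values given here, the only step available, a 1.2-fold higher number from compound 1 to compound 2 (0.08 log units; within the scatter), swaps trifluoromethyl for methoxy at another place, so it bears on the change only indirectly. Since that step from compound 1 stayed at a 1.2-fold higher number from compound 1 to compound 2 (0.08 log units; within the scatter), no step beyond the scatter is expected in this assay, and neither direction is favoured. The expected step is a 1.1-fold lower number from compound 2 to compound 3 (0.03 log units; within the scatter). Compound 3 is estimated at 2200 nM, with an expected range of 900 nM to 5500 nM.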

Compound 3, half-maximal inhibitory concentration: 4820 nM
For compound 3 the middle estimate is 2.2-fold (0.34 log units) below the measured one; the range from low to high includes it.
By their numbers in this assay, from the lowest: compounds 1 and 2 (each within the scatter of the next); then compound 3.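

In this assay the change from 4-fluorophenyl to 4-methoxyphenyl gives a 2.1-fold higher number from compound 2 to compound 3 (0.31 log units; beyond the scatter) and so moves the number toward weaker inhibition. The earlier swap of trifluoromethyl for methoxy at the other place gave only a 1.2-fold higher number from compound 1 to compound 2 (0.08 log units; within the scatter), which makes this position, on an aromatic carbon para to a large group, the first place among these compounds where a single change goes beyond the scatter. No measured evidence accompanies these compounds that could explain this step.

From the compounds shown here alone, what an amine, a hydroxyl or a longer ether chain such as ethoxy would do at this position remains open. So does whether methoxy in place of fluoro would give a similar step on the core of compound 1, which carries methoxy rather than trifluoromethyl at the other place.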